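Trifluoromethyl in Place of Chloro: What to Expect

This account rests on a few compounds, and the source may have more. Where it says the series, first, only, none or still open, it means among the compounds named here.

Of the compounds shown here, three sharing one core have been tested in an assay on isolated protein for inhibition of alpha-ketoglutarate-dependent dioxygenase alkB homolog 3 (Homo sapiens), read by polymerase chain reaction, with a stated time of 1 h; on this read-out higher numbers stand for weaker inhibition and lower numbers for stronger inhibition. Compound 1 `Cc1[nH]n(-c2nc3ccccc3[nH]2)c(=O)c1Cc1ccccc1Cl` carries a 2-chlorophenyl group on a saturated chain carbon bound to an aromatic carbon, and in this assay compound 1 reaches only the limit > 10000 nM. Compound 3 `Cc1[nH]n(-c2nc3ccccc3[nH]2)c(=O)c1Cc1ccc(Cl)cc1` carries 4-chlorophenyl at that place, and in this assay compound 3 also gives only the limit > 10000 nM. The step that the two limits leave unreadable from compound 1 to compound 3 therefore cannot be read. Compound 2 `Cc1[nH]n(-c2nc3ccccc3[nH]2)c(=O)c1Cc1ccc(-c2ccccc2)cc1` has phenyl where compound 3 has chloro, and in this assay compound 2 gives 720 nM. The step of an at least 13-fold higher number from compound 2 to compound 3 (1.14 log units; beyond the scatter) is large, so compound 3 stands at the weak end of the numbers shown: the limit of > 10000 nM in this assay, at which 2 of the 3 values shown sit.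

Compound 4 `Cc1[nH]n(-c2nc3ccccc3[nH]2)c(=O)c1Cc1ccc(C(F)(F)F)cc1` differs from compound 3 by trifluoromethyl in place of chloro on an aromatic carbon. Within the data shown here, no measured step exchanges these two groups directly, so the only guide is that compound 2 shows a clearly stronger number with phenyl at this place. With compound 3 sitting at a limit, compound 4 is expected to move only modestly, the estimated step being an at least 1.2-fold lower number from compound 3 to compound 4 (0.09 log units; that floor lies within the scatter). Compound 4 is therefore estimated at 8000 nM, within a range from 2000 nM to 30000 nM, and a further limit rather than a number is quite possible.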

Compound 4, half-maximal inhibitory concentration: 550 nM
Beside the measured number, compound 4's estimate is 15-fold (1.16 log units) above it; the whole stated range lies above it.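

Exchanging chloro for trifluoromethyl on this aromatic carbon gives an at least 18-fold lower number from compound 3 to compound 4 (1.25 log units; beyond the scatter), so phenyl is not the only group shown that brings a measurable number at this place. Trifluoromethyl and phenyl cannot be told apart here, with a 1.3-fold lower number from compound 2 to compound 4 (0.12 log units; within the scatter), and trifluoromethyl has no ring, so a second ring is not needed for a value in this range. The size of the step from chloro is a floor and not a measured gap, and compound 3 is still known only as a limit: the limit of > 10000 nM in this assay, at which 2 of the 4 values shown sit.

The compounds shown do not tell how other groups at this place would behave, such as methoxy, an amine, a carboxylic acid or a longer chain, or whether any of them could go clearly beyond the level shared by compound 2 and compound 4. Neither chloro nor trifluoromethyl brings a hydrogen-bond donor, a hydrogen-bond acceptor or a net charge. These four compounds offer no other measurement that separates the two groups, and they leave the large gap between them unexplained.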